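Replacing pyridin-2-yl with 3,4-dichlorophenyl on the shared core

The compounds below may be only part of what the source reports. "The series", "measured", "known", "first", "only" and "open" are said of these compounds alone.

In a functional assay on HT-29 cells (Homo sapiens) for antiproliferative activity, read by MTT assay, with a stated time of 24 h (a lower number here means a stronger inhibitor, a higher number a weaker inhibitor), compound 3 `COc1ccc(C(=O)/C=C/c2ccccn2)c2c1C=CC(C)(C)O2` gives 2120 nM and compound 2 `COc1ccc(C(=O)/C=C/c2ccc(N(C)C)cc2)c2c1C=CC(C)(C)O2` gives 1870 nM, and a 1.1-fold higher number from compound 2 to compound 3 (0.05 log units; within the scatter) places the two level. Compound 1 `COc1ccc(C(=O)/C=C/c2ccc(F)cc2)c2c1C=CC(C)(C)O2` gives > 10000 nM, which is a limit of the assay. Compound 4 `COc1ccc(C(=O)/C=C/c2ccc(Cl)c(Cl)c2)c2c1C=CC(C)(C)O2` differs from compound 3 as follows: 3,4-dichlorophenyl in place of pyridin-2-yl on a double-bonded chain carbon bound to a double-bonded chain carbon. The closest guide is compound 1, which also carries a halogen on its phenyl ring. Leaving it produced an at least 4.7-fold lower number from compound 1 to compound 3 (0.67 log units; beyond the scatter), and likewise an at least 5.3-fold lower number from compound 1 to compound 2 (0.72 log units; beyond the scatter), both beyond the scatter. A move back to a halogenated phenyl ring is therefore expected to raise the number modestly, with an estimated 2.4-fold higher number from compound 3 to compound 4 (0.37 log units; beyond the scatter). Compound 4 is expected at 5000 nM, with an estimated range from 1800 nM to 14000 nM.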

Compound 4, half-maximal inhibitory concentration: 7580 nM
Beside the measured number, compound 4's estimate is 1.5-fold (0.18 log units) below it, and the stated range covers the measured number.
By their numbers in this assay, from the lowest: compounds 2 and 3 (each within the scatter of the next); then compound 4. At a limit, above all of these: compound 1.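

In this assay 3,4-dichlorophenyl on the double-bonded chain carbon gives a 3.6-fold higher number from compound 3 to compound 4 (0.55 log units; beyond the scatter) and it likewise gives a 4.1-fold higher number from compound 2 to compound 4 (0.61 log units; beyond the scatter) as well. Going by these compounds alone, compound 4 thus supplies the first actual number for a halogenated phenyl ring at this place, and that number lies on the weaker side of compound 2 and compound 3. Compound 1 stands at a limit of the assay: the limit of > 10000 nM in this assay, at which 1 of the 4 values shown sits.

Against that limit, an at least 1.3-fold lower number from compound 1 to compound 4 (0.12 log units; that floor lies within the scatter) is all that can be stated, so no order can be given for this pair.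

The compounds shown leave open how a phenyl ring carrying a hydroxyl group or a morpholine would behave here. They also leave open whether pyridin-3-yl would stay level with pyridin-2-yl.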